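A Chloro Joins the Trifluoromethyl on the Urea Aryl Ring

This account rests on a few compounds, and the source may have more. Where it says the series, first, only, none or still open, it means among the compounds named here.

Compound 1, `O=C(Nc1cccc(-n2cc(-c3ccncc3)c(-c3ccc(Cl)c(O)c3)n2)c1)Nc1cccc(C(F)(F)F)c1`: > 32500 nM
Compound 2, `O=C(Nc1cccc(-n2cc(-c3ccncc3)c(-c3ccc(Cl)c(O)c3)n2)c1)Nc1cc(C(F)(F)F)cc(C(F)(F)F)c1`: 6060 nM

In a functional assay on M14 cells (Homo sapiens) for inhibition, read by sulforhodamine B assay, with a stated time of 48 h (a lower number here means that less compound is tolerated, a higher number that more compound is tolerated), compound 1 sits at a limit of the measurement, (the limit of > 32500 nM in this assay, at which 1 of the 2 values shown sits), so only a bound is known for it. For the measured compounds named here, the one measured step on the same ring is an at least 5.3-fold lower number from compound 1 to compound 2 (0.72 log units; beyond the scatter). Compound 3, `O=C(Nc1cccc(-n2cc(-c3ccncc3)c(-c3ccc(Cl)c(O)c3)n2)c1)Nc1ccc(Cl)c(C(F)(F)F)c1`, differs from compound 1 by chloro in place of hydrogen on an aromatic carbon. Because an at least 5.3-fold lower number from compound 1 to compound 2 (0.72 log units; beyond the scatter) lowered the number beyond the scatter, a smaller move in the same direction is expected for compound 3, namely an at least 2.7-fold lower number from compound 1 to compound 3 (0.43 log units; beyond the scatter). Compound 3 is therefore estimated at 12000 nM, with a likely range from 4000 nM to 32500 nM.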

Compound 3, concentration lethal to 50% of the cells: > 32500 nM
Compound 3: only a limit was reported (the forecaster's own chance of this, stated with the estimate: 30%); middle value at least 2.7-fold (0.43 log units) from the limit.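

In this assay compound 3 gives > 32500 nM, which is a limit and not a number. For the compounds shown here, compound 1 stands at the same limit, so no step between compound 1 and compound 3 can be read: the limit of > 32500 nM in this assay, at which 2 of the 3 values shown sit. Whether chloro in place of hydrogen changes the number at all stays open.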